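A few compounds are considered here, and "the series" means these few. Any claim that something is new, unique, unknown or untested is made for them only; others in the source may bear on it.

Measured compounds:
- compound 1 `CCOc1ccccc1N1CCN(CCCCn2ncc(=O)n(C)c2=O)CC1`: 1.8 nM
- compound 2 `Cn1c(=O)cnn(CCCCN2CCN(c3ccccc3OCCCF)CC2)c1=O`: 280 nM
- compound 3 `CNc1ccccc1N1CCN(CCCCn2ncc(=O)n(C)c2=O)CC1`: 450 nM

Compound 2 stands second highest of the three numbers in an assay for displacement of a labelled ligand from Adrenergic receptor alpha-1 (Homo sapiens); a lower number here means a stronger inhibitor, a higher number a weaker inhibitor. Its nearest neighbour is compound 3 a 1.6-fold higher number from compound 2 to compound 3 (0.21 log units; within the scatter), and its furthest is compound 1, the gap being a 160-fold higher number from compound 1 to compound 2 (2.19 log units; beyond the scatter). Compound 1 thus carries the lowest number of the series by a wide margin.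

The next compound, compound 4 `Cn1c(=O)cnn(CCCCN2CCN(c3ccccc3F)CC2)c1=O`, differs from compound 2 by fluoro in place of 3-fluoropropoxy on an aromatic carbon.

For the measured compounds named here, no measured step replaces the whole alkoxy chain by a single atom, so the evidence is indirect. Compound 1 with ethoxy gives the low number; lengthening that chain gives a 160-fold higher number from compound 1 to compound 2 (2.19 log units; beyond the scatter), and exchanging it for methylamino gives a 250-fold higher number from compound 1 to compound 3 (2.40 log units; beyond the scatter). Both point to the group on that aromatic carbon governing most of the spread. Cutting it back to fluoro removes the part that separated compound 2 from compound 1, but also removes the ethoxy that compound 1 carries, so a return all the way to the number of compound 1 is not expected. A moderate decrease in this assay from compound 2 is expected, a 4.7-fold lower number from compound 2 to compound 4 (0.67 log units; beyond the scatter). Compound 4 is estimated at 60 nM, with a range from 10 nM to 400 nM.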

Compound 4, inhibition constant: 9.73 nM
For compound 4 the middle estimate is 6.2-fold (0.79 log units) above the measured one; measured number outside the range, below it.
By their numbers in this assay, from the lowest: compound 1; then compound 4; then compounds 2 and 3 (each within the scatter of the next).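

Replacing the chain on this aromatic carbon with fluoro brings a large drop in this assay from both of the weaker compounds (a 29-fold lower number from compound 2 to compound 4 (1.46 log units; beyond the scatter)) and (a 46-fold lower number from compound 3 to compound 4 (1.67 log units; beyond the scatter)), so this position accepts a single fluoro far better than 3-fluoropropoxy or methylamino. Ethoxy still holds a modest advantage over fluoro (a 5.4-fold higher number from compound 1 to compound 4 (0.73 log units; beyond the scatter)), which places compound 4 in a middle rank and shows that the lowest number in this series does not belong to the smallest group. No measurement in hand accounts for these differences.

Methoxy, chloro or plain hydrogen on this aromatic carbon would show whether the lowest number is particular to ethoxy or extends to other small groups. A propoxy chain without the terminal fluorine would separate the contribution of the longer chain from that of the fluorine in compound 2, and the compounds shown cannot make that separation.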